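Aryl Amides on a Shared Core Against Colon Cancer Cells

The source may hold more compounds than are shown below. What is called first, only, known or untested is meant among the compounds shown, and "the series" means these compounds.

Measured compounds:
compound 1, `CCC(=O)N(C)c1ccc2[nH]c(-c3n[nH]c4ccccc34)cc2n1`: 10800 nM
compound 2, `COc1ccc(C(=O)N(C)c2ccc3[nH]c(-c4n[nH]c5ccccc45)cc3n2)cc1`: 29500 nM

In a functional assay on HCT-116 cells (Homo sapiens) for antiproliferative activity, read by MTT assay, with a stated time of 72 h (on this read-out lower numbers stand for stronger inhibition and higher numbers for weaker inhibition), compound 1 gives 10800 nM and compound 2 gives 29500 nM. Compound 2 thus stands at the higher of the two numbers, reached through a 2.7-fold higher number from compound 1 to compound 2 (0.44 log units; beyond the scatter). Compound 3 `CN(C(=O)c1ccc([N+](=O)[O-])cc1)c1ccc2[nH]c(-c3n[nH]c4ccccc34)cc2n1` differs from compound 2 by nitro in place of methoxy on an aromatic carbon. For the measured compounds named here, no measured step exchanges one substituent on the aryl ring for another; the one step available, a 2.7-fold higher number from compound 1 to compound 2 (0.44 log units; beyond the scatter), alters the group on the carbonyl carbon and does not bear directly on this change. The expected step to compound 3 is a 1.2-fold lower number from compound 2 to compound 3 (0.07 log units; within the scatter), within the scatter. Compound 3 is estimated at 25000 nM, ranging from 8000 nM to 80000 nM.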

Compound 3, half-maximal inhibitory concentration: 19900 nM
Compound 3: middle estimate off by 1.3-fold (0.10 log units), on the high side, and the stated range covers the measured number.
By their numbers in this assay, from the lowest: compounds 1, 3 and 2 (each within the scatter of the next, the first and the last beyond it).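

With the aryl amide kept, nitro in place of methoxy on the aromatic carbon, para to a large group, stays within the scatter (a 1.5-fold lower number from compound 2 to compound 3 (0.17 log units; within the scatter)), so this position shows no clear sensitivity to this exchange. Measured against the ethyl amide, the 4-nitrophenyl group also stays within the scatter (a 1.8-fold higher number from compound 1 to compound 3 (0.27 log units; within the scatter)), unlike the 4-methoxyphenyl group (a 2.7-fold higher number from compound 1 to compound 2 (0.44 log units; beyond the scatter)). Nothing available explains these numbers. From the compounds shown here alone, whether an amine or a carboxylic acid on this aromatic carbon would move the number beyond the scatter remains open. So does the effect of a longer chain in place of ethyl on the carbonyl carbon.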